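Swapping the amide aryl ring: phenyl to pyridyl

The source may hold more compounds than are shown below. What is called first, only, known or untested is meant among the compounds shown, and "the series" means these compounds.

Measured so far:
- compound 1, `Cc1noc(C)c1-c1cnc(N)c(Oc2ccc(C(=O)Nc3ccc(Cl)cc3)cc2)n1`: in a functional assay on HeLa cells (Homo sapiens) for inhibition, read by MTT assay, with a stated time of 72 h (a higher number here means a weaker inhibitor, a lower number a stronger inhibitor), compound 1 gives 2230 nM
- compound 2, `Cn1cc(-c2cnc(N)c(Oc3ccc(C(=O)Nc4ccccc4)cc3)n2)cn1`: compound 2 gives 12300 nM
- compound 3, `Cn1cc(-c2cnc(N)c(Oc3ccc(C(=O)Nc4ccc(Cl)cc4)cc3)n2)cn1`: compound 3 gives 3440 nM

Compound 3 sits between the other two in this assay: its number is within the scatter of compound 1, as the step of a 1.5-fold higher number from compound 1 to compound 3 (0.19 log units; within the scatter) shows, while the step of a 3.6-fold lower number from compound 2 to compound 3 (0.55 log units; beyond the scatter) places it clearly apart from compound 2.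

Compound 4 is `Cn1cc(-c2cnc(N)c(Oc3ccc(C(=O)Nc4ccc(Cl)cn4)cc3)n2)cn1`. It differs from compound 3 in one place: 5-chloropyridin-2-yl in place of 4-chlorophenyl on an amide-type nitrogen. Among the compounds with values here, no measured step covers this kind of change. The step from compound 1 to compound 3 concerns a different ring on a different part of the molecule, and the step from compound 2 to compound 3 concerns the chlorine, which compound 4 keeps. The two steps that are known therefore only show that small ring changes elsewhere stayed within the scatter and that the chlorine mattered. With the chlorine retained and the amide ring only exchanged for its pyridine counterpart, compound 4 is expected to land near compound 3, with a step of a 1.2-fold higher number from compound 3 to compound 4 (0.07 log units; within the scatter) that is not expected to exceed the scatter. Compound 4 is estimated at 4000 nM, within a range from 1500 nM to 11000 nM.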

Compound 4, half-maximal inhibitory concentration: 21500 nM
The estimate for compound 4 lay 5.4-fold (0.73 log units) below the measured number, and the stated range ends below it.
By their numbers in this assay, from the lowest: compounds 1 and 3 (each within the scatter of the next); then compounds 2 and 4 (each within the scatter of the next).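

The amide-type nitrogen turns out to be sensitive to a small edit in its ring: exchanging 4-chlorophenyl for 5-chloropyridin-2-yl, which swaps one ring carbon for a nitrogen and adds a hydrogen-bond acceptor, gives a 6.3-fold higher number from compound 3 to compound 4 (0.80 log units; beyond the scatter) in this assay and so a clearly weaker inhibitor. The chlorine alone therefore does not secure the better number, even though adding it to the phenyl ring gave a 3.6-fold lower number from compound 2 to compound 3 (0.55 log units; beyond the scatter), since the step of a 1.7-fold higher number from compound 2 to compound 4 (0.24 log units; within the scatter) lies within the scatter and leaves the chlorinated pyridine ring no different from the plain phenyl ring of compound 2. Nothing measured on these compounds accounts for the loss, so the step stands as an observation without an explanation.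

On these data alone, it remains open whether the same loss appears when 3,5-dimethyl-1,2-oxazol-4-yl takes the place of 1-methyl-1H-pyrazol-4-yl on the shared core. Also open, as far as these compounds go, is what a pyridin-2-yl ring without chlorine would give, or a pyridine ring carrying an amine or a methoxy group in place of the chlorine.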